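The compounds below may be only part of what the source reports. "The series", "measured", "known", "first", "only" and "open" are said of these compounds alone.

Compound 1, `C=C1CCCC(C)(C)C1CC[C@]1(C)CC[C@@H]([C@@H](C)C(=O)O)OO1`, carries a free acid on a bicyclic core that lacks the third ring. In a functional assay on OVCAR-4 cells (Homo sapiens) for inhibition (a higher number here means a weaker inhibitor of growth, a lower number a stronger inhibitor of growth), compound 1 gives only a limit, > 10000 nM, so no number is known for it. Compound 2, `C=C1CCCC(C)(C)C1CC[C@]1(C)CC[C@H]([C@@H](C)C(=O)OC)OO1`, bears the methyl ester on the same core with the other configuration at the peroxide-bearing ring carbon, and in this assay compound 2 gives 4010 nM. Compound 3, `C=C1CCC[C@H]2[C@](C)(CC[C@]3(C)CC[C@@H]([C@@H](C)C(=O)O)OO3)[C@@H](C)CC[C@]12C`, returns to the free acid on a tricyclic core; in this assay compound 3 gives 950 nM, the lowest of the two numbers, and its distance from compound 2 is beyond the scatter.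

Compound 4, `C=C1CCC[C@H]2[C@](C)(CC[C@]3(C)CC[C@H]([C@@H](C)C(=O)O)OO3)[C@@H](C)CC[C@]12C`, has not yet been measured. Compared with compound 3, (the two compounds have the same atoms and bonds and differ only in configuration as drawn: 1 of 7 stereo elements differ; a stereocentre at a saturated ring carbon is drawn S in compound 3 and R in compound 4). The two compounds share all atoms and bonds, so the change is confined to that single centre.

Within the data shown here, no measured pair in this set differs only in that stereocentre, so the size of the step in this assay can only be guessed. A shift of modest size, in either direction, is expected, with a slight lean toward a weaker compound 4. The expected step of a 1.6-fold higher number from compound 3 to compound 4 (0.20 log units; within the scatter) reflects that. Compound 4 is thus estimated at 1500 nM, within a range from 400 nM to 6000 nM.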

Compound 4, concentration for 50% growth inhibition: 1890 nM
Compound 4: middle estimate off by 1.3-fold (0.10 log units), on the low side; low and high end bracket the measured number.
By their numbers in this assay, from the lowest: compounds 3 and 4 (each within the scatter of the next); then compound 2. At a limit, above all of these: compound 1.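

Among these compounds, this is the first pair in the set that isolates the configuration at the saturated ring carbon, drawn S in compound 3 and R in compound 4, and in this assay the result is a 2.0-fold higher number from compound 3 to compound 4 (0.30 log units; within the scatter). With the free acid and the shared core held constant, inverting this single centre therefore leaves growth inhibition within the usual spread of repeated measurements, so the data give no firm preference for either configuration here. The comparison isolates this one centre, as nothing else varies between the two compounds: the fact that compounds 3 and 4 differ only in the configuration as drawn

Compound 1 gives only a limit, > 10000 nM, and it differs from compound 2 in more than one place, so whether this centre matters on the core of compound 1 cannot be read. Also open, as far as these compounds go, is whether the configuration would remain of so little consequence on the shared core of compound 3 and compound 4 if a primary amide or a primary alcohol stood in place of the carboxylic acid.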